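Triazole thioethers: oxime versus benzoyl, phenyl versus ethyl

The compounds below may be only part of what the source reports. "The series", "measured", "known", "first", "only" and "open" are said of these compounds alone.

Measured compounds:
Compound 1, `COc1ccc(-c2nnc(SCC(=O)c3ccccc3)n2-c2ccccc2)cc1OC`, in a functional assay on the whole organism (strain albino) for inhibition, with Rattus norvegicus as the target, read by paw edema, with a stated time of 2 h, at a dose of 0.28 mmol/kg by the oral route (a lower number here means less inhibition, a higher number more inhibition at the dose given (going by the name of the read-out)), gives 57%.
Compound 2, `COc1ccc(-c2nnc(SC/C(=N/O)c3ccccc3)n2-c2ccccc2)cc1OC`, in this assay gives 61%.
Compound 3, `CCn1c(SC/C(=N/O)c2ccccc2)nnc1-c1ccc(OC)c(OC)c1`, in this assay gives 67%.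

All three numbers lie within the usual scatter of one another, so none of the three can be set apart as stronger or weaker. Compound 2 and compound 3 share the oxime-bearing side chain and differ only in the group on the aromatic nitrogen: ethyl in place of phenyl on an aromatic nitrogen. The step that goes with it, a number 6 percentage points higher from compound 2 to compound 3 (within the scatter), is within the scatter. Compound 2 and compound 1 share the phenyl on the aromatic nitrogen and differ only in the side chain, where (a group of 8 heavy atoms (7 carbon, 1 oxygen; one six-membered aromatic ring of carbon only) in place of a group of 9 heavy atoms (7 carbon, 1 nitrogen, 1 oxygen; one six-membered aromatic ring of carbon only), on a saturated chain carbon bound to a sulfur); the step of a number 4 percentage points lower from compound 2 to compound 1 (within the scatter) is also within the scatter.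

Compound 4, `CCn1c(SCC(=O)c2ccccc2)nnc1-c1ccc(OC)c(OC)c1`, is not yet measured. It stands to compound 3 as compound 1 stands to compound 2: a group of 8 heavy atoms (7 carbon, 1 oxygen; one six-membered aromatic ring of carbon only) in place of a group of 9 heavy atoms (7 carbon, 1 nitrogen, 1 oxygen; one six-membered aromatic ring of carbon only), on a saturated chain carbon bound to a sulfur. The place is the same, word for word, as in the step from compound 2 to compound 1, so this is the same change made on the other core, the two cores differing by ethyl in place of phenyl on an aromatic nitrogen. Since the earlier step, a number 4 percentage points lower from compound 2 to compound 1 (within the scatter), was within the scatter, the step from compound 3 to compound 4 is expected to be of about the same size, a number 4 percentage points lower from compound 3 to compound 4 (within the scatter), and likewise within the scatter. On that basis compound 4 is estimated to give 63% in this assay, with a likely span from 50% to 75%.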

Compound 4, a percentage reported as inhibition, in the whole organism at one dose (the size of the read-out at that dose, not a potency): 55%
Estimate against measurement, compound 4: 8 percentage points above, and the stated range covers the measured number.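

In this assay, putting benzoyl in place of the oxime-bearing group on a saturated chain carbon bound to a sulfur gives a number 12 percentage points lower from compound 3 to compound 4 (beyond the scatter) on the core with ethyl on the aromatic nitrogen, a modest step, while the same change on the core with phenyl there stayed within the scatter, yet the two steps cannot be told apart: the same change on two cores in this assay, a number 4 percentage points lower (within the scatter) from compound 2 to compound 1 and a number 12 percentage points lower (beyond the scatter) from compound 3 to compound 4, 8 percentage points apart, within the scatter of two such steps. Ethyl in place of phenyl on an aromatic nitrogen, read with benzoyl in the side chain, gives a number 2 percentage points lower from compound 1 to compound 4 (within the scatter), and this too agrees with the same change read with the oxime-bearing side chain: the same change on two cores in this assay, a number 6 percentage points higher (within the scatter) from compound 2 to compound 3 and a number 2 percentage points lower (within the scatter) from compound 1 to compound 4, 8 percentage points apart, within the scatter of two such steps. Both changes therefore carry from one core to the other without a detectable difference in step size, but with one pair of steps for each change this does not show that the steps are equal, nor does it establish that the benzoyl change matters more on the ethyl core.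

As far as these compounds go, whether the picture holds for a longer chain or a benzyl group on the aromatic nitrogen, or for a carboxylic acid or an amine on the saturated chain carbon bound to a sulfur, stays open. The read-out also gives the size of inhibition at one dose and one stated time, which leaves potency and the time course of the effect open.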